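Para-chloro on the phenyl of a sigma-1 ligand

The source may hold more compounds than are shown below. What is called first, only, known or untested is meant among the compounds shown, and "the series" means these compounds.

Within the data shown here, compound 1 `COC(=O)C1(c2ccccc2)CC1CN1CCC(Cc2ccccc2)CC1` is measured in an assay for displacement of a labelled ligand from Sigma non-opioid intracellular receptor 1 (Cavia porcellus) (on this read-out lower numbers stand for stronger inhibition and higher numbers for weaker inhibition), and gives 2.2 nM, the only number recorded. Compound 2 `COC(=O)C1(c2ccc(N)cc2)CC1CN1CCN(c2ccccn2)CC1` reaches only the limit of this assay, > 10000 nM, a limit rather than a number. Compound 3 `COC(=O)C1(c2ccc(Cl)cc2)CC1CN1CCC(Cc2ccccc2)CC1` is not yet measured; it differs from compound 1 by chloro in place of hydrogen on an aromatic carbon, on an aromatic carbon para to a large group. Among the measured compounds shown here, with no measured step of that kind, the step from compound 1 to compound 3 is expected to stay within the scatter, a 1.1-fold lower number from compound 1 to compound 3 (0.04 log units; within the scatter). Compound 3 is therefore estimated at 2 nM, between 0.5 nM and 8 nM.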

Compound 3, inhibition constant: 0.82 nM
For compound 3 the middle estimate is 2.4-fold (0.39 log units) above the measured one; low and high end bracket the measured number.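

Chloro in place of hydrogen on an aromatic carbon para to a large group gives, in this assay, a 2.7-fold lower number from compound 1 to compound 3 (0.43 log units; beyond the scatter), the only measured step at this position. The position therefore accepts a chlorine atom, and a number that was already low moves further down. Nothing shown here gives a cause for this step. As far as these compounds go, whether a fluorine atom, a methyl or a methoxy group at the same place would move the number in the same direction stays open, as does whether the step carries over to a core other than that of compound 1.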